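This account rests on a few compounds, and the source may have more. Where it says the series, first, only, none or still open, it means among the compounds named here.

Measured in an ADME assay on L6 cells (Rattus norvegicus) for cytotoxicity, read by resazurin assay, with a stated time of 72 h; a higher number here means a weaker inhibitor, a lower number a stronger inhibitor:
- compound 1 `CCc1ccc(C(=O)NC(=O)c2ccccc2O)cc1`: 70 ug/mL
- compound 2 `Cc1ccc(C(=O)NC(=O)c2ccccc2O)cc1`: 46 ug/mL

Only these two compounds have been measured, and they cannot be told apart: the measured step is a 1.5-fold lower number from compound 1 to compound 2 (0.18 log units; within the scatter). Compound 1 therefore stands level with compound 2 within the scatter.

The next compound is compound 3 `CCc1ccc(C(=O)N(C)C(=O)c2ccccc2O)cc1`, with this change from compound 1: methyl in place of hydrogen on an amide-type nitrogen. In words, this is methyl in place of hydrogen on an amide-type nitrogen.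

Within the data shown here, no measured step touches that nitrogen. Among the measured compounds shown here, the single step available, a 1.5-fold lower number from compound 1 to compound 2 (0.18 log units; within the scatter), lies on the saturated chain, so it is only a weak guide to size and none to direction. With compound 1 at 70 ug/mL as the anchor, no step beyond the scatter is expected in this assay, though with wide uncertainty. The expected change is a 1.2-fold lower number from compound 1 to compound 3 (0.07 log units; within the scatter). For compound 3 the estimated value is 60 ug/mL, with an expected range of 25 ug/mL to 110 ug/mL.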

Compound 3, half-maximal inhibitory concentration: 9.4 ug/mL
Compound 3: middle estimate off by 6.4-fold (0.81 log units), on the high side; the measured number lies below the stated range.
By their numbers in this assay, from the lowest: compound 3; then compounds 2 and 1 (each within the scatter of the next).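

Among these compounds, on the amide-type nitrogen whose other neighbours are two carbonyl carbons, methyl in place of hydrogen gives a 7.4-fold lower number from compound 1 to compound 3 (0.87 log units; beyond the scatter) in this assay and is the only step so far that lies beyond the scatter. The change on the saturated chain, a 1.5-fold lower number from compound 1 to compound 2 (0.18 log units; within the scatter), stays within the scatter, so this nitrogen is the one place shown where a single change separates two compounds in this series. Loss of the amide hydrogen thus goes with a stronger inhibitor of L6 cells here, although this rests on one pair, and nothing measured bears on the cause of the step.

As far as these compounds go, whether an ethyl group, a longer chain or an acetyl group on this nitrogen would move the number the same way remains open. From the compounds shown here alone, it is also open whether the same methyl change would give a comparable step on the core of compound 2.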